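Removing the Nitro Group from Compound 2

A few compounds are considered here, and "the series" means these few. Any claim that something is new, unique, unknown or untested is made for them only; others in the source may bear on it.

Compound 1 `O=[N+]([O-])c1ccc(COc2ccc(Nc3ncnc4cc5c(cc34)OCCOCCO5)cc2)cc1` gave no number in a functional assay on HepG2 cells (Homo sapiens) for antiproliferative activity, read by MTT assay, with a stated time of 72 h (on this read-out higher numbers stand for weaker inhibition and lower numbers for stronger inhibition), but only the assay's limit, > 100000 nM. Compound 2 `O=[N+]([O-])c1ccc(COc2ccccc2Nc2ncnc3cc4c(cc23)OCCOCCOCCO4)cc1` gave 60800 nM, the higher of the two numbers seen in this assay; compound 3 `FC(F)(F)c1ccc(COc2ccc(Nc3ncnc4cc5c(cc34)OCCOCCOCCOCCO5)cc2)cc1` gave 3340 nM, a gap beyond the usual scatter. Compound 4 `c1ccc(COc2ccccc2Nc2ncnc3cc4c(cc23)OCCOCCOCCO4)cc1` has not yet been measured. It differs from compound 2 in one place only: hydrogen in place of nitro on an aromatic carbon. For the measured compounds named here, no measured pair shows this same change, so the expected size of the step rests on compound 2 alone. A modest move toward weaker inhibition in this assay is expected, close to the scatter, with a 1.5-fold higher number from compound 2 to compound 4 (0.17 log units; within the scatter). Compound 4 is therefore estimated at 90000 nM, between 25000 nM and 300000 nM, with a real chance that only the assay's limit is reported.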

Compound 4, half-maximal inhibitory concentration: 37300 nM
Beside the measured number, compound 4's estimate is 2.4-fold (0.38 log units) above it; measured number inside the range.
By their numbers in this assay, from the lowest: compound 3; then compounds 4 and 2 (each within the scatter of the next). At a limit, above all of these: compound 1.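

In this assay, replacing nitro with hydrogen on this ring gives a 1.6-fold lower number from compound 2 to compound 4 (0.21 log units; within the scatter). The nitro group in this place, para to a large group, is therefore not required for the activity seen with compound 2, since the pair cannot be told apart from the scatter. Both numbers lie near the assay's ceiling, which leaves little room for any loss to show: the limit of > 100000 nM in this assay, at which 1 of the 4 values shown sits.

Going by these compounds, what an amine or a carboxylic acid in this place would give remains open. So does whether the same change would behave alike on the cores of compound 1 and compound 3.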